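Adding a Methoxy Group to Compound 2: Expected Rat Exposure

This account rests on a few compounds, and the source may have more. Where it says the series, first, only, none or still open, it means among the compounds named here.

Compound 1 `C=CC(=O)N1CC[C@H](N2C(=O)N(Cc3ccccc3)Cc3cnc(Nc4ccc(N5CCN(C)CC5)cc4OC)nc32)C1`: 359 ng.h/mL
Compound 2 `C=CC(=O)N1CC[C@H](N2C(=O)N(c3ccccc3)Cc3cnc(Nc4ccc(N5CCN(C)CC5)cc4)nc32)C1`: 857 ng.h/mL

In an ADME assay on the whole organism (plasma, strain Sprague-Dawley) for pharmacokinetics, with Rattus norvegicus as the target, read by LC-MS, at a dose of 5 mg/kg by the intravenous route (on this read-out lower numbers stand for lower exposure and higher numbers for higher exposure at the dose given), compound 2 gives 857 ng.h/mL, the higher of the two numbers recorded so far. Compound 1 gives 359 ng.h/mL in this assay, and the gap between the two lies beyond the usual scatter; compound 1 and compound 2 differ from each other in more than one place, so no single change connects them. Compound 3 `C=CC(=O)N1CC[C@H](N2C(=O)N(c3ccccc3)Cc3cnc(Nc4ccc(N5CCN(C)CC5)cc4OC)nc32)C1` has not yet been measured in this assay. It differs from compound 2 by methoxy in place of hydrogen on an aromatic carbon. Going by the values given here, with no one-point step between the measured compounds, the expectation can rest only on the two values above and on the size of the change. A step of a 1.6-fold lower number from compound 2 to compound 3 (0.19 log units; within the scatter) is expected in this assay, a modest drop that may not clear the scatter. Compound 3 is expected to give 550 ng.h/mL in this assay, within a range from 250 ng.h/mL to 1200 ng.h/mL.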

Compound 3, area under the concentration-time curve: 962 ng.h/mL
For compound 3 the middle estimate is 1.7-fold (0.24 log units) below the measured one, and the stated range covers the measured number.
By their numbers in this assay, from the lowest: compound 1; then compounds 2 and 3 (each within the scatter of the next).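

In this assay, methoxy in place of hydrogen on an aromatic carbon, ortho to a large group and meta to a 4-methylpiperazin-1-yl group, gives a 1.1-fold higher number from compound 2 to compound 3 (0.05 log units; within the scatter) and so shows no separation from the scatter at this position. Phenyl in place of benzyl on an amide-type nitrogen in a ring, with the methoxy present on both sides of the change, gives a 2.7-fold higher number from compound 1 to compound 3 (0.43 log units; beyond the scatter) and is the only one-point step of the two that clears the scatter. Nothing measured here accounts for either step.

The compounds shown leave open whether a different group at this position, such as fluorine, ethoxy or a dimethylamino group, would stay within the scatter as methoxy does. They also leave open whether methoxy in place of hydrogen would give a similar step with benzyl on the ring nitrogen.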